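The source may report more compounds than this note shows. Statements on the series, on what has been measured and on what is new or still open speak of the compounds shown alone.

In a functional assay, with stated times of 30 s and 6 min, in the presence of a further agent that is not named here (a lower number here means a stronger inhibitor, a higher number a weaker inhibitor), three compounds have been measured so far. Compound 1 `CCCCCCOc1cc(OC)c(Br)cc1C(C)=O` gives 34000000 nM, compound 2 `CCCCCCCCCCOc1cc(OC)c(Br)cc1C(C)=O` gives 15000000 nM, and compound 3 `CCCCCCOc1cc(OC)ccc1C(C)=O` gives 18000000 nM. Compound 3 cannot be separated from either of the others. Its value lies within the usual scatter of compound 2, and the same holds against compound 1, as shown by a 1.9-fold lower number from compound 1 to compound 3 (0.28 log units; within the scatter). Only compound 1 and compound 2 are told apart from each other.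

Compound 4 `CCCCCCCCCCOc1cc(OC)ccc1C(C)=O` differs from compound 3 by a single change: butyl in place of hydrogen on a saturated chain carbon, six bonds along the chain from an oxygen on an aromatic ring. The same change has been measured once before, in a 2.3-fold lower number from compound 1 to compound 2 (0.36 log units; beyond the scatter), a modest step just beyond the scatter. That pair carries a bromo group on the aromatic carbon where compound 3 and compound 4 carry hydrogen, so the match is not exact. Swapping bromo for hydrogen gave no step beyond the scatter, which gives no reason to set that precedent aside, although one pair is thin evidence. A similar modest move towards a lower number is therefore expected, and it could still end up within the scatter. The expected size of this move is a 2.3-fold lower number from compound 3 to compound 4 (0.35 log units; beyond the scatter). For compound 4, the estimated value is 8000000 nM, with an expected range of 3500000 nM to 16000000 nM.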

Compound 4, half-maximal inhibitory concentration: 26600000 nM
Compound 4: the middle estimate sits 3.3-fold (0.52 log units) below what was measured; the measured number lies above the stated range.
By their numbers in this assay, from the lowest: compounds 2, 3, 4 and 1 (each within the scatter of the next, the first and the last beyond it).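

In this assay, butyl in place of hydrogen on this saturated chain carbon gives a 1.5-fold higher number from compound 3 to compound 4 (0.17 log units; within the scatter), so on the core without bromo the longer chain makes no difference that can be read. The earlier step therefore does not carry over to this core, and the effect of adding butyl here depends on what sits on the aromatic carbon: the same change on two cores in this assay, a 2.3-fold lower number (0.36 log units; beyond the scatter) from compound 1 to compound 2 and a 1.5-fold higher number (0.17 log units; within the scatter) from compound 3 to compound 4, 3.3-fold (0.52 log units) apart, beyond the scatter of two such steps The bromo position looks different in the same way, with hydrogen in place of bromo giving a 1.8-fold higher number from compound 2 to compound 4 (0.25 log units; within the scatter), a step that can be read only alongside the earlier one on the shorter chain, and the two do not agree: the same change on two cores in this assay, a 1.9-fold lower number (0.28 log units; within the scatter) from compound 1 to compound 3 and a 1.8-fold higher number (0.25 log units; within the scatter) from compound 2 to compound 4, 3.3-fold (0.52 log units) apart, beyond the scatter of two such steps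

On these data alone, each of these comparisons rests on a single pair of steps, and each step is small, so it remains open whether this dependence between chain and bromo group would hold up on further compounds. As far as these compounds go, it also remains open whether a chloro group in place of bromo, an octyl chain, or a chain ending in an amine or a carboxylic acid would move the number beyond the scatter on both cores.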